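Moving a methyl around the benzyl ring

This account rests on a few compounds, and the source may have more. Where it says the series, first, only, none or still open, it means among the compounds named here.

Compound 1 `Cc1noc(C)c1-c1ccc2c(c1)c(CCc1ccc(F)cc1)cn2CCCCCCC(=O)NO` gives 15500 nM in a functional assay on THP-1 cells (Homo sapiens) for inhibition; on this read-out higher numbers stand for weaker inhibition of growth and lower numbers for stronger inhibition of growth. Compound 2 `Cc1ccccc1Cc1cn(CCCCCCC(=O)NO)c2ccc(-c3c(C)noc3C)cc12` stands level with it, giving 15500 nM in this assay; the step of no change at the digits printed from compound 1 to compound 2 (within the scatter) lay within the scatter. Compound 3 `Cc1ccc(Cc2cn(CCCCCCC(=O)NO)c3ccc(-c4c(C)noc4C)cc23)cc1` is drawn next, differing from compound 2 only by 4-methylphenyl in place of 2-methylphenyl on a saturated chain carbon bound to an aromatic carbon. Among the compounds with values here, the one measured step bears on this change only loosely, since it swapped whole groups on the same carbon and still left the read-out unchanged. Compound 3 is therefore expected to show no change at the digits printed from compound 2 to compound 3 (within the scatter), nothing beyond the scatter, and its estimated value is 15500 nM within 7000 nM to 33000 nM.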

Compound 3, concentration for 50% growth inhibition: 15500 nM
Estimate against measurement, compound 3: no gap at the digits printed; the measured number falls inside the stated range.
By their numbers in this assay, from the lowest: compounds 1, 2 and 3 (each within the scatter of the next).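

In this assay, going from 2-methylbenzyl to 4-methylbenzyl on this saturated chain carbon leaves the read-out flat (no change at the digits printed from compound 2 to compound 3 (within the scatter)), so it does not separate these two placements of the methyl. The wider exchange for the group of compound 1 reads the same way (no change at the digits printed from compound 1 to compound 3 (within the scatter)). Nothing available here accounts for this flat read-out. The compounds shown leave open whether an amine or a carboxylic acid on the benzyl ring would carry the read-out beyond the scatter.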